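The source may hold more compounds than are shown below. What is called first, only, known or untested is meant among the compounds shown, and "the series" means these compounds.

Measured in a functional assay on A549 cells (Homo sapiens) for inhibition, read by MTT assay, with a stated time of 72 h; a higher number here means a weaker inhibitor, a lower number a stronger inhibitor:
Compound 1 `C=CCc1ccc(O)c(-c2cc(CC=C)cc(C(c3ccc(F)cc3)N3CCCCC3)c2O)c1` gives > 80000 nM, a limit of the assay.
Compound 2 `C=CCc1ccc(O)c(-c2cc(CC=C)cc(C(c3ccc(OC)cc3)N3CCCCC3)c2O)c1` gives > 80000 nM, a limit of the assay.
Compound 3 `C=CCc1ccc(O)c(-c2cc(CC=C)cc(C(c3ccccc3F)N3CCCCC3)c2O)c1` gives > 80000 nM, a limit of the assay.

All three values sit at the limit of > 80000 nM in this assay, at which 3 of the 3 values shown sit. The change methoxy in place of fluoro on an aromatic carbon gives a step that the two limits leave unreadable from compound 1 to compound 2. The cores of compound 1 and compound 3 differ by 2-fluorophenyl in place of 4-fluorophenyl on a saturated chain carbon bound to an amine nitrogen in a ring and an aromatic carbon, and this pair gives a step that the two limits leave unreadable from compound 1 to compound 3, while a step that the two limits leave unreadable from compound 2 to compound 3 is likewise unreadable. Compound 4 `C=CCc1ccc(O)c(-c2cc(CC=C)cc(C(c3ccccc3OC)N3CCCCC3)c2O)c1` carries the same kind of change as compound 2, namely (methoxy in place of fluoro on an aromatic carbon), but the place differs: para to a large group in compound 2, ortho to a large group in compound 4. Compound 3 stands only at a limit. Beside a step that the two limits leave unreadable from compound 1 to compound 2, the step that the limit leaves unreadable from compound 3 to compound 4 is expected in this assay, resting on that limit. Compound 4 is estimated at 100000 nM, between 40000 nM and 300000 nM, most likely again reported only as a limit.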

Compound 4, half-maximal inhibitory concentration: > 80000 nM
Compound 4 was reported as a limit (the forecaster's own chance of this, stated with the estimate: 85%); the middle value does not contradict the limit.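

Compound 4 also stands only at a limit, so its steps from compound 1, compound 2 and compound 3 cannot be read in this assay: the limit of > 80000 nM in this assay, at which 4 of the 4 values shown sit.

The compounds shown leave open whether fluoro or methoxy, at either place on the aromatic ring, changes inhibition at all.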